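The compounds below may be only part of what the source reports. "The series", "measured", "known", "first", "only" and "open" are said of these compounds alone.

Two measured members of the series frame the question. Compound 1 `COc1c(NS(=O)(=O)C2CC2)cc(-c2ccc3nc(NC(C)=O)nn3c2)cc1C(N)=O` carries a cyclopropylsulfonyl group on the sulfonamide nitrogen; in a functional assay on HCT-116 cells (Homo sapiens) for antiproliferative activity, read by MTT assay, with a stated time of 72 h (a higher number here means a weaker inhibitor, a lower number a stronger inhibitor), compound 1 gives 36300 nM, the highest of the two numbers in hand. Compound 2 `COc1c(NS(=O)(=O)c2ccc(F)cc2)cc(-c2ccc3nc(NC(=O)C4CC4)sc3n2)cc1C(N)=O` differs from it at several places at once, the core among them, and in this assay compound 2 gives 2500 nM, a lower number that lies beyond the scatter. Because the two differ in more than one place, the gap between them cannot be assigned to any single change.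

Compound 3 `COc1c(NS(=O)(=O)c2ccc(Cl)cc2)cc(-c2ccc3nc(NC(C)=O)nn3c2)cc1C(N)=O` keeps the core and the acetamide of compound 1 and alters a single group: 4-chlorophenyl in place of cyclopropyl on a sulfonyl sulfur. Going by the values given here, no measured pair isolates this change. Among the compounds with values here, the only measured compound with an aryl group on the sulfonyl sulfur is compound 2, and its lower number is confounded by its different core, so only a tempered expectation can be drawn from it.

A move toward a lower number is expected, of size a 4.0-fold lower number from compound 1 to compound 3 (0.61 log units; beyond the scatter). Compound 3 is accordingly estimated at 9000 nM, with a range of 2500 nM to 33000 nM.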

Compound 3, half-maximal inhibitory concentration: 31700 nM
The estimate for compound 3 lay 3.5-fold (0.55 log units) below the measured number; measured number inside the range.
By their numbers in this assay, from the lowest: compound 2; then compounds 3 and 1 (each within the scatter of the next).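

Read in this assay, the swap of cyclopropyl for 4-chlorophenyl on a sulfonyl sulfur gives a 1.1-fold lower number from compound 1 to compound 3 (0.06 log units; within the scatter) and is the first single-place reading at this position in the series. On the core and acetamide of compound 1, a group with one six-membered aromatic ring of carbon only and a group with one three-membered non-aromatic ring therefore read alike, so this exchange alone does not supply a number beyond the scatter. Compound 2 still differs from compound 3 at several places, its core among them, so the pair assigns its value to no single change, and nothing measured here bears on why the step is so small.

On these data alone, whether a methyl group, a longer alkyl chain, or a phenyl ring carrying an amine or a carboxylic acid on the sulfonyl sulfur would move the number on this core remains open. Also open, as far as these compounds go, are the separate contributions of the core and of the acetamide, which need compounds that change only one of them.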